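The compounds below may be only part of what the source reports. "The series", "measured", "known", "first", "only" and "open" are said of these compounds alone.

Compound 1 `CC(C)c1ccc(C[C@H](C)C(=O)N[C@@H]2O[C@H](CO)[C@@H](O)[C@H](O)[C@H]2O)cc1` gives 0.143 in a physicochemical assay for lipophilicity, measured as octanol-water partition; a lower number here means a more polar compound, a higher number a more lipophilic compound. Compound 2 `CC(C)(C)c1ccc(/C=C/C(=O)N[C@@H]2O[C@H](CO)[C@@H](O)[C@H](O)[C@H]2O)cc1` gives 0.496 in this assay. Compound 3 `CC(C)c1ccc(/C=C/C(=O)N[C@@H]2O[C@H](CO)[C@@H](O)[C@H](O)[C@H]2O)cc1` gives 0.296 in this assay.

Compound 1 stands lowest of the three numbers, with compound 3 nearest and compound 2 furthest. The difference between the core of compound 1 and the core of compound 3 is not broken down here. Within the measured set, one change can be isolated: from compound 3 to compound 2 the change is methyl in place of hydrogen on a saturated chain carbon bound to an aromatic carbon and two saturated chain carbons, and it brought a number 0.20 log units higher from compound 3 to compound 2 (within the scatter).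

Compound 4 `C[C@@H](Cc1ccc(C(C)(C)C)cc1)C(=O)N[C@@H]1O[C@H](CO)[C@@H](O)[C@H](O)[C@H]1O` has not yet been measured in this assay. Among the compounds with values here, it differs from compound 1 by methyl in place of hydrogen on a saturated chain carbon bound to an aromatic carbon and two saturated chain carbons, which is the same change as the one made from compound 3 to compound 2, at the same place. Among the compounds shown this change occurs twice in all. Since the measured step from compound 3 to compound 2 lies within the scatter, the expectation for compound 4 rests on a step of about that size applied to compound 1: compound 4 is expected to show a number 0.20 log units higher from compound 1 to compound 4 (within the scatter) in this assay. On that basis compound 4 is estimated at 0.34 in this assay, with the estimate placed between 0.1 and 0.6.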

Compound 4, partition coefficient: 0.379
Beside the measured number, compound 4's estimate is 0.04 log units below it; low and high end bracket the measured number.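

In this assay the change from isopropyl to tert-butyl was read on two cores: it gave a number 0.20 log units higher from compound 3 to compound 2 (within the scatter) on one and a number 0.24 log units higher from compound 1 to compound 4 (within the scatter) on the other, so in both pairs the step has the same direction as printed and stays within the scatter, and the reading from the first core carried over to the second without conflict. This does not show that the change has a real effect on the number in either core, since neither step rises beyond the scatter, and two pairs that share the same change cannot establish a rule for the series or show that the step would hold on any further core. Nothing measured here bears on why the two steps read as they do.

The compounds shown leave open how the number would respond to a group of a different kind at this place, such as an amine, a carboxylic acid or a longer chain in place of the tert-butyl. Within the data shown here, they also leave open what the difference between the core of compound 1 and the core of compound 3 contributes taken on its own, as no single step isolates it.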